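Chloro in Place of Methoxy: An Expectation for Compound 4

The source may hold more compounds than are shown below. What is called first, only, known or untested is meant among the compounds shown, and "the series" means these compounds.

Of the compounds shown here, three have been measured in an assay on isolated protein for binding affinity to 5-hydroxytryptamine receptor 1D (Homo sapiens); a higher number here means a weaker inhibitor, a lower number a stronger inhibitor. Compound 1 `Cc1ccc(-c2n[nH]cc2N2CCCNCC2)cc1` gives 892 nM in this assay. Compound 2 `COc1ccccc1-c1n[nH]cc1N1CCCNCC1` returns only a limit in this assay, > 10000 nM. Compound 3 `COc1ccccc1-c1n[nH]cc1N1CCNCC1` likewise reaches only a limit in this assay, > 10000 nM. Compound 3 thus stands at the weak end of what is shown, at the limit where two of the three values sit (the limit of > 10000 nM in this assay, at which 2 of the 3 values shown sit); no number for it is known, and no step between measured compounds that differ in a single place has been computed.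

Compound 4 `Clc1ccccc1-c1n[nH]cc1N1CCNCC1` differs from compound 3 in one place: chloro in place of methoxy on an aromatic carbon of a six-membered aromatic ring of carbon only, ortho to a large group. Nothing measured here tells how such an exchange shifts binding. Going by the values given here, the expected step, an at least 1.6-fold lower number from compound 3 to compound 4 (0.22 log units; that floor lies within the scatter), is therefore small or none beyond the scatter, since compound 3 starts from a limit and no comparable step is available. Compound 4 is expected to give about 6000 nM in this assay, within a range from 1500 nM to 20000 nM, with a fair chance that only a limit is again reported.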

Compound 4, inhibition constant: > 10000 nM
Compound 4 was reported as a limit; the forecaster's own chance of this, stated with the estimate: 45%; middle value at least 1.6-fold (0.22 log units) away from the limit.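

Going by these compounds alone, compound 3 and compound 4 are both reported only as limits in this assay, so no step between them can be read: the limit of > 10000 nM in this assay, at which 3 of the 4 values shown sit.

The compounds shown leave open whether chloro in place of methoxy on an aromatic carbon shifts binding at all, and how far compound 3 and compound 4 lie from each other.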